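Dimethylamino for amino on a fused two-ring core

The source may report more compounds than this note shows. Statements on the series, on what has been measured and on what is new or still open speak of the compounds shown alone.

Compound 1, `CC(=O)Nc1nc2ccccn2c1-c1ccc(O)cc1`: in an assay on isolated protein for inhibition of ubiquitin carboxyl-terminal hydrolase 1 (Homo sapiens) (on this read-out lower numbers stand for stronger inhibition and higher numbers for weaker inhibition), compound 1 gives only the limit > 100000 nM.
Compound 2, `Nc1nc2ccccn2c1-c1ccc(O)cc1`: in this assay compound 2 gives only the limit > 100000 nM.

Compound 2 therefore stands at a limit of this assay, not at a number. Among the compounds with values here, the single change that connects it to compound 1, hydrogen in place of acetyl on a nitrogen on an aromatic ring, gives a step that the two limits leave unreadable from compound 1 to compound 2, so nothing about the size or direction of that step can be read. Within the data shown here, the only evidence on the measured step is the limit of > 100000 nM in this assay, at which 2 of the 2 values shown sit.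

The next compound, compound 3, `CN(C)c1nc2ccccn2c1-c1ccc(O)cc1`, differs from compound 2 by dimethylamino in place of amino on an aromatic carbon. Among the measured compounds shown here, no measured step bears on this change, and both values so far are limits. The step that the limit leaves unreadable from compound 2 to compound 3 is accordingly expected to be unreadable rather than a sized change. For compound 3 the estimate in this assay is 150000 nM, with a range from 30000 nM to 1000000 nM, and most likely the assay will again report only a limit.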

Compound 3, half-maximal inhibitory concentration: > 100000 nM
Compound 3 was reported as a limit; the forecaster's own chance of this, stated with the estimate: 85%; the middle value does not contradict the limit.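

In this assay compound 3 gives > 100000 nM, which is a limit and not a number. The steps connecting compound 1, compound 2 and compound 3 cannot be read, in either size or direction. The compounds shown leave open whether any compound with the shared core gives a measurable value in this assay.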